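The compounds below may be only part of what the source reports. "The series", "measured", "known", "first", "only" and "open" are said of these compounds alone.

Notes on the series

The shared core of compound 1 `CN(C(=O)NC(=O)c1ccccc1F)c1nc(C(F)(F)F)c(C(=O)N/N=C/c2cc(C(F)(F)F)cc(C(F)(F)F)c2)s1` carries an acyl urea whose aryl group is varied across the set. In a functional assay on HepG2 cells (Homo sapiens) for inhibition, read by MTT assay, with a stated time of 72 h (a higher number here means a weaker inhibitor, a lower number a stronger inhibitor), compound 1 gives 4.47 ug/mL. Compound 3 `CN(C(=O)NC(=O)c1cccc(C(F)(F)F)c1)c1nc(C(F)(F)F)c(C(=O)N/N=C/c2cc(C(F)(F)F)cc(C(F)(F)F)c2)s1` gives 5.38 ug/mL in this assay. Compound 2 `CN(C(=O)NC(=O)c1ccc(Cl)cc1Cl)c1nc(C(F)(F)F)c(C(=O)N/N=C/c2cc(C(F)(F)F)cc(C(F)(F)F)c2)s1` gives only a limit of the assay, > 100 ug/mL in this assay. The two plain numbers sit close: a 1.2-fold higher number from compound 1 to compound 3 (0.08 log units; within the scatter), so compound 3 stands as the higher of the two numbers but within the scatter of compound 1. The large changes are an at least 22-fold higher number from compound 1 to compound 2 (1.34 log units; beyond the scatter) and an at least 18-fold lower number from compound 2 to compound 3 (1.26 log units; beyond the scatter); these rest on (the limit of > 100 ug/mL in this assay, at which 1 of the 3 values shown sits).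

Compound 4 `CN(C(=O)NC(=O)c1ccc(C(F)(F)F)cc1)c1nc(C(F)(F)F)c(C(=O)N/N=C/c2cc(C(F)(F)F)cc(C(F)(F)F)c2)s1` is the next member. The change from compound 3 is 4-(trifluoromethyl)phenyl in place of 3-(trifluoromethyl)phenyl on a carbonyl carbon. For the measured compounds named here, no measured step moves a trifluoromethyl group around the ring; the steps measured so far exchange the whole substitution pattern. The step from compound 1 to compound 3 lies within the scatter, while the steps to and from compound 2 are large but concern a different substitution. For compound 4 the expected value in this assay is 6 ug/mL, with a range from 2.5 ug/mL to 15 ug/mL. The step expected for compound 4 is therefore a 1.1-fold higher number from compound 3 to compound 4 (0.05 log units; within the scatter), that is, no change clearly beyond the scatter.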

Compound 4, half-maximal inhibitory concentration: 8.35 ug/mL
Compound 4: the middle estimate sits 1.4-fold (0.14 log units) below what was measured, within the range that was stated.
By their numbers in this assay, from the lowest: compounds 1, 3 and 4 (each within the scatter of the next). At a limit, above all of these: compound 2.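

Moving the trifluoromethyl group, with 4-(trifluoromethyl)phenyl in place of 3-(trifluoromethyl)phenyl on a carbonyl carbon, is the first measured change that keeps the same substituent and the same atoms, and in this assay it gives a 1.6-fold higher number from compound 3 to compound 4 (0.19 log units; within the scatter). The comparison with the fluorinated aryl group adds a 1.9-fold higher number from compound 1 to compound 4 (0.27 log units; within the scatter), so the 2-fluorophenyl, 3-(trifluoromethyl)phenyl and 4-(trifluoromethyl)phenyl groups are not told apart by this read-out. The 2,4-dichlorophenyl group remains the only one that stands apart, now also against the 4-(trifluoromethyl)phenyl group, with an at least 11-fold lower number from compound 2 to compound 4 (1.07 log units; beyond the scatter), and this step rests on a limit and not on a number: the limit of > 100 ug/mL in this assay, at which 1 of the 4 values shown sits.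

The compounds shown leave open whether a monochlorophenyl group would read with the 2,4-dichlorophenyl group or with the other three aryl groups in this assay. Also open, going by these compounds, is how an unsubstituted phenyl group, or an aryl group carrying an amine or a carboxylic acid, would read on this carbonyl carbon.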